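Phenyl in place of hydrogen: compound 1 to compound 4

A few compounds are considered here, and "the series" means these few. Any claim that something is new, unique, unknown or untested is made for them only; others in the source may bear on it.

Compound 1 `O=C(O)Cc1sc(Cc2ccccc2)nc1-c1ccc(Cl)cc1` gives 4100 nM in an in vitro functional assay on HEK285-7 cells for antagonist activity at prostaglandin D2 receptor 2 (Homo sapiens), read by BRET and beta-arrestin recruitment (a higher number here means a weaker inhibitor, a lower number a stronger inhibitor), the highest of the three numbers measured. Compound 2 `O=C(O)Cc1sc(Cc2ccc(Cl)cc2)nc1-c1ccc(Cl)cc1` gives 220 nM and compound 3 `O=C(O)Cc1sc(Cc2ccccc2)nc1-c1ccc(F)cc1` gives 180 nM; the step of a 19-fold lower number from compound 1 to compound 2 (1.27 log units; beyond the scatter) and the step of a 23-fold lower number from compound 1 to compound 3 (1.36 log units; beyond the scatter) are both beyond the scatter.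

Compound 4 `O=C(O)Cc1sc(Cc2ccccc2-c2ccccc2)nc1-c1ccc(Cl)cc1` differs from compound 1 by phenyl in place of hydrogen on an aromatic carbon. Neither measured step bears directly on this change: the step from compound 1 to compound 2 adds a chloro on the ring that carries the new phenyl in compound 4, but at a different carbon, and the step from compound 1 to compound 3 alters the other aryl ring. Both steps show that a single change to one of the two aryl rings can move the number substantially, yet nothing measured tells the direction for a phenyl ortho to a large group. A step in this assay is expected, most likely downward as for the two known ring changes, but with wide uncertainty. Compound 4 is therefore estimated at 1500 nM, within 300 nM to 8000 nM, which is an expected step of a 2.7-fold lower number from compound 1 to compound 4 (0.44 log units; beyond the scatter).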

Compound 4, half-maximal inhibitory concentration: 510 nM
Compound 4: the middle estimate sits 2.9-fold (0.47 log units) above what was measured; the measured number falls inside the stated range.
By their numbers in this assay, from the lowest: compounds 3 and 2 (each within the scatter of the next); then compound 4; then compound 1.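

In this assay, phenyl in place of hydrogen on an aromatic carbon, ortho to a large group, gives an 8.0-fold lower number from compound 1 to compound 4 (0.91 log units; beyond the scatter), which is beyond the scatter. The earlier steps shown here showed the effect of exchanging only chloro and fluoro groups, whereas this result shows that a whole six-membered aromatic ring of 6 heavy atoms can enter at this carbon and the number still falls, in the same direction as those two steps. No supporting data are available to explain the drop, and the result alone does not say which feature of the phenyl group matters.

Open, as far as these compounds go, is whether the drop requires an aromatic ring at this carbon, which a methyl, a methoxy or a cyclohexyl group at the same carbon would address, as would a pyridyl ring for the all-carbon nature of the ring. Also open, from the compounds shown here alone, is how phenyl behaves at the carbon that carries chloro in compound 2, and whether the phenyl change adds to the change from chloro to fluoro seen in compound 3.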